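Methoxy for chloro on an inactive naphthol amide series

A few compounds are considered here, and "the series" means these few. Any claim that something is new, unique, unknown or untested is made for them only; others in the source may bear on it.

The shared core of compound 1 `O=C(Nc1cc(Sc2ncnc3nc[nH]c23)c(O)c2ccccc12)c1ccc(Cl)cc1` carries a chlorobenzamide; in a functional assay on HCT-116 cells (Homo sapiens) for antiproliferative activity, read by MTT assay, with a stated time of 48 h (on this read-out lower numbers stand for stronger inhibition and higher numbers for weaker inhibition), compound 1 gives only the limit > 100000 nM. Compound 3 `O=C(Nc1cc(Sc2ncnc3nc[nH]c23)c(O)c2ccccc12)c1ccc([N+](=O)[O-])cc1` sits at the same limit, > 100000 nM. The step that the two limits leave unreadable from compound 1 to compound 3 is therefore not readable, since the limit of > 100000 nM in this assay, at which 3 of the 3 values shown sit, holds both ends. Compound 2 `O=C(Nc1cc(Sc2ncn[nH]2)c(O)c2ccccc12)c1cccc(Cl)c1` likewise reports only the limit > 100000 nM in this assay. Compound 4 `COc1cccc(C(=O)Nc2cc(Sc3ncn[nH]3)c(O)c3ccccc23)c1` differs from compound 2 by methoxy in place of chloro on an aromatic carbon, meta to a large group. No measured step gives a readable size to compare with, and every shown value is a limit. Compound 4 is therefore expected to remain at or near the same limit, an estimate of 150000 nM with a range of 30000 nM to 1000000 nM; the expected step that the limit leaves unreadable from compound 2 to compound 4 is thus essentially none beyond the scatter.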

Compound 4, half-maximal inhibitory concentration: > 100000 nM
Compound 4: only a limit was reported (the forecaster's own chance of this, stated with the estimate: 85%); the middle value does not contradict the limit.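

The step between compound 2 and compound 4 cannot be read, as both report only a limit in this assay: the limit of > 100000 nM in this assay, at which 4 of the 4 values shown sit.

The compounds shown leave open how methoxy and chloro compare on this core, since none of them gives a value inside the range of this assay.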